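The compounds below may be only part of what the source reports. "The series", "measured", "known", "first", "only" and "open" are said of these compounds alone.

Series notes on the cinnamamide-bearing set. Compound 1 `O=C(/C=C/c1ccc([N+](=O)[O-])cc1)Nc1cc2c(Nc3ccc(F)c(Cl)c3)ncnc2cc1O[C@H]1CCOC1` gives 26700 nM in a functional assay on MCF7 cells (Homo sapiens) for cytotoxicity, read by MTT assay, with a stated time of 72 h (a lower number here means a stronger inhibitor, a higher number a weaker inhibitor), a weak result. Compound 2 `COc1cc2ncnc(Nc3ccc(F)c(Cl)c3)c2cc1NC(=O)/C=C/c1ccc(F)cc1Cl` is reported in this assay only as "not active" (no number reported), with no number attached, so compound 2 stands at the weak end of the two measured compounds without a figure to anchor it.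

Compound 3 `COc1cc2ncnc(Nc3ccc(F)c(Cl)c3)c2cc1NC(=O)/C=C/c1ccccc1[N+](=O)[O-]` is the next member. It differs from compound 2 in one place: 2-nitrophenyl in place of 2-chloro-4-fluorophenyl on a double-bonded chain carbon bound to a double-bonded chain carbon. Compound 1 already shows that a nitrophenyl on the chain, in a related context, gives only weak inhibition at 26700 nM, and compound 2 has no number from which a step could be sized. With that, no shift beyond the scatter is expected in either direction from compound 2 to compound 3; compound 3 is expected to remain weak, with a real chance of another limit-only result.

Compound 3 is estimated at 35000 nM, with a range from 10000 nM to 120000 nM.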

Compound 3, half-maximal inhibitory concentration: 36500 nM
The estimate for compound 3 lay 1.0-fold (0.02 log units) below the measured number; low and high end bracket the measured number.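

In this assay, among the compounds shown here, compound 3 gives 36500 nM and compound 2 carries only a "not active" report with no number, so no step from compound 2 to compound 3 can be read. The compounds shown leave open how far 2-nitrophenyl and 2-chloro-4-fluorophenyl differ at this place on a numerical scale. No measurement at hand bears on a cause for this result.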